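The source may hold more compounds than are shown below. What is called first, only, known or untested is meant among the compounds shown, and "the series" means these compounds.

Compound 1 `O=C(Nc1cccc(-n2cc(-c3ccncc3)c(-c3cc(O)cc(Cl)c3)n2)c1)Nc1ccc(Cl)c(C(F)(F)F)c1` was tested in a functional assay on NCI-H226 cells (Homo sapiens) for inhibition, read by sulforhodamine B assay, with a stated time of 48 h, tested at 1 uM (on this read-out lower numbers stand for a stronger effect and higher numbers for a weaker effect at the one concentration tested), and gave 96% there, a weak effect on this read-out. Compound 2 `O=C(Nc1cccc(-n2cc(-c3ccncc3)c(-c3cc(O)cc(Cl)c3)n2)c1)Nc1ccc(Cl)c(Cl)c1`, which carries a chloro in place of the trifluoromethyl on an aromatic carbon, gave 96% in this assay; the step of no change at the digits printed from compound 1 to compound 2 (within the scatter) shows that this exchange made no difference within the scatter. Going by the values given here, compound 1 therefore stands level with compound 2 at the digits printed, and compound 2 is its only measured neighbour.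

Compound 3 `COc1cc(Cl)cc(-c2nn(-c3cccc(NC(=O)Nc4ccc(Cl)c(C(F)(F)F)c4)c3)cc2-c2ccncc2)c1` differs from compound 1 in a different place: methyl in place of hydrogen on an oxygen on an aromatic ring. Among the compounds with values here, no measured step touches this oxygen, so the one available step, from compound 1 to compound 2, does not bear on the change directly; it only shows that the series sits at a weak effect. With nothing to indicate a shift, the expected step of a number 1 percentage points lower from compound 1 to compound 3 (within the scatter) is none beyond the scatter. For compound 3 the value expected in this assay is 95%, with a range from 80% to 105%.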

Compound 3, a percentage reported as activity, at one concentration (the size of the read-out at that concentration, not a potency): 79%
Compound 3: the middle estimate sits 16 percentage points above what was measured, outside the stated range (below it).
By their numbers in this assay, from the lowest: compound 3; then compounds 1 and 2 (each within the scatter of the next).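

Replacing hydroxy with methoxy on the 3-chloro-5-hydroxyphenyl group gave a stronger effect in this assay, with a number 17 percentage points lower from compound 1 to compound 3 (beyond the scatter). Going by these compounds alone, the earlier exchange of trifluoromethyl for chloro elsewhere in the molecule, with no change at the digits printed from compound 1 to compound 2 (within the scatter), had left the read-out unmoved, so this oxygen is the first place where a single change, here the addition of one carbon as a methyl, shifts the number beyond the scatter. No evidence is available to explain this shift.

On these data alone, it remains open whether a longer chain on this oxygen, such as ethoxy, or a chain ending in an amine or a carboxylic acid would carry the effect further. Also open, as far as these compounds go, is whether chloro in place of trifluoromethyl would still make no difference with the methoxy group present.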